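A few compounds are considered here, and "the series" means these few. Any claim that something is new, unique, unknown or untested is made for them only; others in the source may bear on it.

Measured so far:
compound 1, `Nc1scc(CN2CCN(c3ccc(Cl)cc3Cl)CC2)c1C(=O)c1ccc(Cl)cc1`, 0%
compound 2, `Nc1scc(CN2CCN(c3cccnc3)CC2)c1C(=O)c1ccc(Cl)cc1`, 0%

Both values come from an assay on CHO cells for displacement of a labelled ligand from adenosine receptor A3 (Homo sapiens), read by scintillation counting, with a stated time of 120 min, tested at 10 uM; on this read-out higher numbers stand for more inhibition at the one concentration tested (going by the name of the read-out) and lower numbers for less inhibition. Compound 2 stands level with compound 1 at the digits shown; the step of no change at the digits printed from compound 1 to compound 2 (within the scatter) lies within the scatter, so nothing in this pair separates the two aryl groups on the ring nitrogen.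

Compound 3 is `Nc1scc(CN2CCN(c3cc(F)cc(F)c3)CC2)c1C(=O)c1ccc(Cl)cc1`. It differs from compound 2 in one place: 3,5-difluorophenyl in place of pyridin-3-yl on an amine nitrogen in a ring. Within the data shown here, the only measured step that bears on this change is no change at the digits printed from compound 1 to compound 2 (within the scatter), which also exchanged one aryl group for another on the same ring nitrogen and left the read-out where it was. Because compound 2 gives 0% and that earlier exchange was flat, compound 3 is expected to stay at the same level, with a step of no change at the digits printed from compound 2 to compound 3 (within the scatter), none beyond the scatter. The estimate for compound 3 in this assay is 0%, with a range from 0% to 15%.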

Compound 3, a percentage reported as inhibition, at one concentration (the size of the read-out at that concentration, not a potency): 2%
The estimate for compound 3 lay 2 percentage points below the measured number, and the stated range covers the measured number.
By their numbers in this assay, from the lowest: compounds 1, 2 and 3 (each within the scatter of the next).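

In this assay, 3,5-difluorophenyl on the ring nitrogen gives (a number 2 percentage points higher from compound 2 to compound 3 (within the scatter)) and, set against the dichlorinated aryl group, (a number 2 percentage points higher from compound 1 to compound 3 (within the scatter)). The flat result therefore now extends to a third aryl group: a fluorinated carbon-only ring, a chlorinated carbon-only ring and a pyridine ring with one ring nitrogen are not separated at this position in this read-out at the one concentration tested. Nothing available explains this flat outcome.

As far as these compounds go, whether a group other than a directly attached aromatic ring on this nitrogen, such as a benzyl group or a longer alkyl chain, would shift the read-out beyond the scatter remains open. Also open, from the compounds shown here alone, is whether a change elsewhere on the shared core, such as an amide in place of the free amine, would do so.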